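Substituent at the fused ring: tert-butyl to phenyl

The source may report more compounds than this note shows. Statements on the series, on what has been measured and on what is new or still open speak of the compounds shown alone.

Compound 3 `Cc1c(C(=O)Nc2ccc(Oc3ncnc4[nH]cc(-c5ccccc5)c34)c(F)c2)c(=O)c2cc(C(C)(C)C)ccc2n1C` gives 42 nM in an assay on isolated protein for inhibition of tyrosine-protein kinase receptor UFO (Homo sapiens), read by FRET and Z'-LYTE, with a stated time of 1.5 h (on this read-out higher numbers stand for weaker inhibition and lower numbers for stronger inhibition), the lowest number of the three; compound 2 `Cc1ccc2c(c1)c(=O)c(C(=O)Nc1ccc(Oc3ncnc4[nH]cc(-c5ccccc5)c34)c(F)c1)c(C)n2C` gives 100 nM and compound 1 `Cc1c(C(=O)Nc2ccc(Oc3ncnc4[nH]cc(-c5ccccc5)c34)c(F)c2)c(=O)c2cc(C(F)(F)F)ccc2n1C` gives 150 nM. The steps are a 1.5-fold lower number from compound 1 to compound 2 (0.18 log units; within the scatter), a 3.6-fold lower number from compound 1 to compound 3 (0.55 log units; beyond the scatter) and a 2.4-fold lower number from compound 2 to compound 3 (0.38 log units; beyond the scatter). Compound 4 `Cc1c(C(=O)Nc2ccc(Oc3ncnc4[nH]cc(-c5ccccc5)c34)c(F)c2)c(=O)c2cc(-c3ccccc3)ccc2n1C` carries phenyl in place of tert-butyl on an aromatic carbon, at the position that is meta to a fused ring and para to a fused ring. For the measured compounds named here, both steps that enlarged this group, from methyl or trifluoromethyl to tert-butyl, lowered the number modestly; no measured step places an aromatic ring there. A step of a 1.1-fold lower number from compound 3 to compound 4 (0.02 log units; within the scatter) in this assay is therefore expected, within the scatter or slightly lower. Compound 4 is estimated at 40 nM, range 15 nM to 120 nM.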

Compound 4, half-maximal inhibitory concentration: > 10000 nM
Compound 4 gave a limit, no number; the forecaster's own chance of this, stated with the estimate: 2%; at least 250-fold (2.39 log units) between middle value and limit.
By their numbers in this assay, from the lowest: compound 3; then compounds 2 and 1 (each within the scatter of the next). At a limit, above all of these: compound 4.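

Compound 4 reads only as a limit, not a number: the limit of > 10000 nM in this assay, at which 1 of the 4 values shown sits. The steps to phenyl are large, an at least 230-fold higher number from compound 3 to compound 4 (2.37 log units; beyond the scatter) and an at least 100-fold higher number from compound 2 to compound 4 (2.00 log units; beyond the scatter) and an at least 66-fold higher number from compound 1 to compound 4 (1.82 log units; beyond the scatter). The lower number that came with tert-butyl therefore does not carry over to phenyl at this position, para to a fused ring, so the earlier trend with methyl and trifluoromethyl does not extend to an aromatic ring here.

The compounds shown leave open whether a saturated ring such as cyclohexyl would stay close to compound 3. Going by these compounds, an amine or a carboxylic acid at this position also remains untested in these data.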